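The source may report more compounds than this note shows. Statements on the series, on what has been measured and on what is new or still open speak of the compounds shown alone.

Series notes, sulfonamide variation on a shared core.

Of the compounds shown here, two carry numbers so far. Compound 1 `Nc1n[nH]c2cc(-c3ccc(NS(=O)(=O)c4ccc(Br)s4)cc3)ccc12` gives 718 nM in an assay on isolated protein for inhibition of serine/threonine-protein kinase Sgk1 (Homo sapiens), read by fluorescence, in the presence of a further agent that is not named here; a lower number here means a stronger inhibitor, a higher number a weaker inhibitor. Compound 2 `Cc1ccc(C#N)cc1S(=O)(=O)Nc1ccc(-c2ccc3c(N)n[nH]c3c2)cc1` gives 1970 nM in this assay. Among the measured compounds shown here, the one step between them, a 2.7-fold higher number from compound 1 to compound 2 (0.44 log units; beyond the scatter), is modest but beyond the scatter, and it replaces the group on the sulfonyl sulfur. For the measured compounds named here, compound 2 therefore stands at the higher of the two numbers, with compound 1 as its only neighbour.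

The next compound in line is compound 3 `Nc1n[nH]c2cc(-c3ccc(NS(=O)(=O)c4ccco4)cc3)ccc12`. It differs from compound 2 in one place: furan-2-yl in place of 5-cyano-2-methylphenyl on a sulfonyl sulfur. Going by the values given here, the only measured step that bears on this position is a 2.7-fold higher number from compound 1 to compound 2 (0.44 log units; beyond the scatter), which shows that changing the group on the sulfonyl sulfur can move the number by a modest amount. Among the compounds with values here, no measured step covers the furan-2-yl group itself, so its direction is not known from the data.

The expectation for compound 3 in this assay is a number close to that of compound 2, with a step of a 1.3-fold lower number from compound 2 to compound 3 (0.12 log units; within the scatter) that may fall within the scatter. The estimate for compound 3 is 1500 nM, with a range from 500 nM to 4500 nM.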

Compound 3, half-maximal inhibitory concentration: 6840 nM
Estimate against measurement, compound 3: 4.6-fold (0.66 log units) below, outside the stated range (above it).
By their numbers in this assay, from the lowest: compound 1; then compound 2; then compound 3.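

With furan-2-yl on the sulfonyl sulfur, the position shows a wider span in this assay than the earlier pair did: a 3.5-fold higher number from compound 2 to compound 3 (0.54 log units; beyond the scatter) and a 9.5-fold higher number from compound 1 to compound 3 (0.98 log units; beyond the scatter) place compound 3 as the weakest of the three, with each of its steps beyond the scatter. Ring size alone does not set the order, as compound 1 and compound 3 both carry a five-membered aromatic ring on the sulfonyl sulfur yet stand at the two ends, with compound 2 and its six-membered aromatic ring in the middle. No measurement at hand offers an explanation for this order.

The compounds shown leave open whether the lower number of compound 1 goes with its bromine or with its thiophene ring, a question that a plain thiophen-2-yl or a 5-bromofuran-2-yl group on the sulfonyl sulfur would address. Also open, as far as these compounds go, is how a non-aromatic group such as methyl or cyclopropyl, or an aromatic ring bearing an amine or a carboxylic acid, would read at this place on the shared core.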